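Shrinking a Ring on the Way to Compound 4

The source may hold more compounds than are shown below. What is called first, only, known or untested is meant among the compounds shown, and "the series" means these compounds.

This set of compounds was tested in an assay on isolated protein for inhibition of N-acylethanolamine-hydrolyzing acid amidase (Homo sapiens), read by fluorescence, with a stated time of 90 min; on this read-out higher numbers stand for weaker inhibition and lower numbers for stronger inhibition. Compound 1 `COc1ccc(-c2ccc(CO[C@H]3CC[C@@H](N=C=S)C3)nc2)cc1F` gives 1450 nM, the highest of the three numbers measured. Compound 2 `COc1ccc(-c2ccc(CO[C@H]3C[C@@H](N=C=S)C3)c(F)c2)cc1OC` gives 58.9 nM, a value lower than that of compound 1 by well more than the usual scatter. Compound 3 `COc1ccc(-c2ccc(CO[C@H]3C[C@@H](N=C=S)C3)nc2)nc1` gives 30.4 nM, again far below compound 1. Going by the values given here, no single-point step between any two measured compounds is available, so these comparisons only show what the values themselves show.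

Compound 4 `COc1ccc(-c2ccc(CO[C@H]3C[C@@H](N=C=S)C3)nc2)cc1F` has not yet been measured. It differs from compound 1 in one place: a group of 7 heavy atoms (5 carbon, 1 nitrogen, 1 sulfur; one four-membered non-aromatic ring of carbon only) in place of a group of 8 heavy atoms (6 carbon, 1 nitrogen, 1 sulfur; one five-membered non-aromatic ring of carbon only), on an oxygen on a saturated carbon. The change sits on an oxygen on a saturated carbon whose other neighbour is a saturated chain carbon, and swaps a group with one five-membered non-aromatic ring of carbon only for a group with one four-membered non-aromatic ring of carbon only.

The step from compound 1 to compound 4 is expected to be large and towards stronger inhibition, a 29-fold lower number from compound 1 to compound 4 (1.46 log units; beyond the scatter), because compound 2 at 58.9 nM and compound 3 at 30.4 nM both sit far below compound 1. Compound 4 is therefore estimated at 50 nM in this assay, with a likely range from 15 nM to 200 nM.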

Compound 4, half-maximal inhibitory concentration: 20 nM
For compound 4 the middle estimate is 2.5-fold (0.40 log units) above the measured one, within the range that was stated.
By their numbers in this assay, from the lowest: compounds 4, 3 and 2 (each within the scatter of the next, the first and the last beyond it); then compound 1.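

Replacing the group with one five-membered non-aromatic ring of carbon only by the group with one four-membered non-aromatic ring of carbon only, on an oxygen on a saturated carbon, gives in this assay a 73-fold lower number from compound 1 to compound 4 (1.86 log units; beyond the scatter). The earlier compounds shown here differed from one another in more than one place, so their values could not tie any gap to the ring alone. This pair does, showing that at this position a change of ring size, with the rest of the molecule the same, is enough to move the number well beyond the scatter. No measurement shown here explains why this change has so large an effect.

On these data alone, this is a single pair, so it remains open whether the same ring change would have a similar effect on a different core. As far as these compounds go, it is also open how a six-membered carbon ring, a three-membered carbon ring or an open carbon chain in this place would compare, so the trend with ring size cannot yet be described.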